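Swapping propyl for 5-methylpyridin-2-yl on a sulfonyl sulfur

A few compounds are considered here, and "the series" means these few. Any claim that something is new, unique, unknown or untested is made for them only; others in the source may bear on it.

Values so far in a physicochemical assay for solubility, in phosphate buffer, with a stated time of 24 h, at pH 7.4 (on this read-out lower numbers stand for lower solubility and higher numbers for higher solubility), are these:
- Compound 1 `COc1ccc(-c2ccc(OCc3cc(C(=O)NS(=O)(=O)c4ccc(CN)cc4)oc3C)cc2)cc1` gives (< 0.6 ug/mL), a limit of the assay and not a number.
- Compound 2 `CCCS(=O)(=O)NC(=O)c1cc(COc2ccc(-c3ccc(OC)cc3)cc2)c(C)o1` gives (7 ug/mL).

Among the measured compounds shown here, compound 2 holds the only true number so far. Compound 1 sits at a limit (the limit of < 0.6 ug/mL in this assay, at which 1 of the 2 values shown sits).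

Compound 3 `COc1ccc(-c2ccc(OCc3cc(C(=O)NS(=O)(=O)c4ccc(C)cn4)oc3C)cc2)cc1` has not yet been measured. It carries 5-methylpyridin-2-yl in place of propyl on a sulfonyl sulfur, and the rest of the molecule stays the same.

For the measured compounds named here, one measured step bears on this place. It is large, and it replaced a ring-bearing group with propyl (an at least 11-fold higher number from compound 1 to compound 2 (1.06 log units; beyond the scatter)). Compound 3 puts a ring back on the sulfonyl sulfur, although a different one. Because of an at least 11-fold higher number from compound 1 to compound 2 (1.06 log units; beyond the scatter) a lower number is expected in this assay, but a single step is thin evidence, so the size stays uncertain. The expected change is modest but beyond the scatter (a 2.8-fold lower number from compound 2 to compound 3 (0.45 log units; beyond the scatter)). For compound 3 the estimated value is (2.5 ug/mL), with an expected range from 0.6 ug/mL to 12 ug/mL as its ends.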

Compound 3, solubility: 5 ug/mL
Beside the measured number, compound 3's estimate is 2.0-fold (0.30 log units) below it, and the stated range covers the measured number.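

In this assay, a ring on the sulfonyl sulfur does not by itself go with a value at the bottom of the assay's range: the change from propyl to 5-methylpyridin-2-yl gives a 1.4-fold lower number from compound 2 to compound 3 (0.15 log units; within the scatter), so this swap shows no real effect on the number. Replacing 4-(aminomethyl)phenyl with 5-methylpyridin-2-yl at the same place gives an at least 8.3-fold higher number from compound 1 to compound 3 (0.92 log units; beyond the scatter). A six-membered aromatic ring is present in compound 3 as well, and the large gap seen earlier between the propyl compound and the ring-bearing compound 1 does not appear between the propyl compound and compound 3. The value of compound 1 is a limit of the assay and not a number, so this step has no exact size: the limit of < 0.6 ug/mL in this assay, at which 1 of the 3 values shown sits.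

The compounds shown leave open whether the aminomethyl group or the phenyl ring that carries it sets compound 1 apart, since the two groups compared with it differ from it in more than one feature. A plain phenyl on the sulfonyl sulfur would help to separate those two parts, and a butyl chain in place of propyl would show how far the number follows the length of a simple chain.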